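This account rests on a few compounds, and the source may have more. Where it says the series, first, only, none or still open, it means among the compounds named here.

Compound 1 `Cc1nn(-c2nc(-c3ccc(Cl)c(Cl)c3)c(SC(C)C)s2)c(C(=O)O)c1-c1ccccc1`: 3000 nM in a functional assay on BJAB cells (Homo sapiens) for antiproliferative activity, with a stated time of 4 days; a higher number here means that more compound is needed for the effect, a lower number that less compound is needed
Compound 2 `COc1ccc(C)cc1-c1c(C)nn(-c2nc(-c3ccc(Cl)c(Cl)c3)c(SC(C)C)s2)c1C(=O)O`: 9500 nM
Compound 3 `Cc1nn(-c2nc(-c3ccc(Cl)c(Cl)c3)c(SC(C)C)s2)c(C(=O)O)c1-c1cccc(C(F)(F)F)c1`: 22000 nM

Compound 3 stands at the highest number of the three in this assay: a 2.3-fold higher number from compound 2 to compound 3 (0.36 log units; beyond the scatter) and a 7.3-fold higher number from compound 1 to compound 3 (0.87 log units; beyond the scatter). Compound 4 `Cc1cc(C)cc(-c2c(C)nn(-c3nc(-c4ccc(Cl)c(Cl)c4)c(SC(C)C)s3)c2C(=O)O)c1` differs from compound 3 in one place: 3,5-dimethylphenyl in place of 3-(trifluoromethyl)phenyl on an aromatic carbon. Among the measured compounds shown here, two measured steps bear on this change. The trifluoromethyl group itself raised the number, a 7.3-fold higher number from compound 1 to compound 3 (0.87 log units; beyond the scatter), so its removal points toward a lower number. For the measured compounds named here, a differently substituted phenyl ring also raised the number, a 3.2-fold higher number from compound 1 to compound 2 (0.50 log units; beyond the scatter), and the 3,5-dimethylphenyl of compound 4 has no direct precedent here, so part of that gain may be given back. Compound 4 is therefore expected to give 8000 nM, with a range from 3000 nM to 22000 nM, an expected step of a 2.8-fold lower number from compound 3 to compound 4 (0.44 log units; beyond the scatter).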

Compound 4, half-maximal effective concentration: 2700 nM
For compound 4 the middle estimate is 3.0-fold (0.47 log units) above the measured one; the whole stated range lies above it.
By their numbers in this assay, from the lowest: compounds 4 and 1 (each within the scatter of the next); then compound 2; then compound 3.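

In this assay a substituted phenyl at this position need not raise the number: 3,5-dimethylphenyl gives a 1.1-fold lower number from compound 1 to compound 4 (0.05 log units; within the scatter) and so stands level with plain phenyl, unlike both earlier substituted rings. Among these compounds the identity of the substituents matters, not merely their presence, as the exchange for 3-(trifluoromethyl)phenyl gives an 8.1-fold lower number from compound 3 to compound 4 (0.91 log units; beyond the scatter) and the exchange for 2-methoxy-5-methylphenyl gives a 3.5-fold lower number from compound 2 to compound 4 (0.55 log units; beyond the scatter) in this comparison. Nothing measured here accounts for these differences.

Going by these compounds, it remains open whether a phenyl ring bearing a single methyl would behave like compound 4, and whether an amine or a hydroxyl group on this ring would bring the number lower than in compound 1.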